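Solubility across aryl replacements on the shared core

The source may report more compounds than this note shows. Statements on the series, on what has been measured and on what is new or still open speak of the compounds shown alone.

Compound 3 `COc1cccc(CNCCCNc2ccnc3cc(-c4cccc5ccccc45)ccc23)c1O` gives the highest number of the three measured compounds in a physicochemical assay for solubility, with a stated time of 18 h, at pH 7.4 (a lower number here means a less soluble compound, a higher number a more soluble compound), at 32000 nM. Compound 1 `COc1cccc(CNCCCNc2ccnc3cc(Oc4ccc(Cl)cc4)ccc23)c1O` gives 14500 nM in this assay, and compound 2 `COc1cccc(CNCCCNc2ccnc3cc(Cc4ccc(C#N)cc4)ccc23)c1O` gives 4200 nM. The steps toward compound 3 are a 2.2-fold higher number from compound 1 to compound 3 (0.34 log units; beyond the scatter) and a 7.6-fold higher number from compound 2 to compound 3 (0.88 log units; beyond the scatter), both beyond the scatter; the step of a 3.5-fold lower number from compound 1 to compound 2 (0.54 log units; beyond the scatter) separates the other two compounds.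

Compound 4 `COc1cccc(CNCCCNc2ccnc3cc(Cc4cc(C)cc(C)c4)ccc23)c1O` is not yet measured in this assay. It differs from compound 3 in one place: 3,5-dimethylbenzyl in place of naphthalen-1-yl on an aromatic carbon. The measured step that bears most directly on this change is a 7.6-fold higher number from compound 2 to compound 3 (0.88 log units; beyond the scatter), which runs in the opposite direction, a benzyl group replaced by naphthalen-1-yl. Going by the values given here, compound 4 carries a 3,5-dimethylbenzyl rather than the 4-cyanobenzyl of compound 2, and no measured pair shows what the two methyl groups do in place of the nitrile, which limits how far that step can be carried over. Still, the benzyl-bearing compound 2 sits well below compound 3, and compound 1 also sits below it.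

For compound 4 a lower number than compound 3 is expected, a step of a 4.0-fold lower number from compound 3 to compound 4 (0.60 log units; beyond the scatter) in this assay. The estimated value for compound 4 is 8000 nM, with a range from 2500 nM to 25000 nM.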

Compound 4, solubility: 4200 nM
Compound 4: the middle estimate sits 1.9-fold (0.28 log units) above what was measured, within the range that was stated.
By their numbers in this assay, from the lowest: compounds 2 and 4 (each within the scatter of the next); then compound 1; then compound 3.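

Going by these compounds alone, with a second benzyl-type group at this position, this assay shows no change at the digits printed from compound 2 to compound 4 (within the scatter) for 3,5-dimethylphenyl in place of 4-cyanophenyl, so the read-out does not tell the two methyl groups from the nitrile here, a comparison the earlier compounds could not offer. There is also a 7.6-fold lower number from compound 3 to compound 4 (0.88 log units; beyond the scatter) and a 3.5-fold lower number from compound 1 to compound 4 (0.54 log units; beyond the scatter) in the same notes, the same sizes as the steps seen with compound 2, so the gap from compound 1 and compound 3 is now shared by two differently substituted benzyl compounds and is no longer tied to the 4-cyanobenzyl group alone. Nothing in the available data accounts for these steps.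

In the step from naphthalen-1-yl to 3,5-dimethylbenzyl, the count of aromatic rings and the saturated chain carbon change together, so the compounds shown cannot separate the two, and a phenyl group bound directly to the aromatic carbon would bear on that. On these data alone, whether the benzyl compounds stay together with a carboxylic acid or an amine on the benzyl ring also remains open, since only the nitrile and the two methyl groups are compared there.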